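The source may report more compounds than this note shows. Statements on the series, on what has been measured and on what is new or still open speak of the compounds shown alone.

Of the compounds shown here, three have so far been measured in an in vitro assay on BHK cells for inhibition of Glucagon receptor (Homo sapiens); on this read-out higher numbers stand for weaker inhibition and lower numbers for stronger inhibition. Compound 1 `COC1CCC(N(Cc2ccc(C(=O)NCCC(=O)O)cc2)C(=O)Nc2ccc(OC(F)(F)F)cc2)CC1` gives only a limit in this assay, > 10000 nM. Compound 2 `CCN(CC)C(=O)C1CCC(N(Cc2ccc(C(=O)NCCC(=O)O)cc2)C(=O)Nc2ccc(OC(F)(F)F)cc2)CC1` gives 782 nM, and compound 3 `O=C(O)CCNC(=O)c1ccc(CN(C(=O)Nc2ccc(OC(F)(F)F)cc2)C2CCN(C(=O)C3CC3)CC2)cc1` gives 1980 nM. Of the two real numbers, compound 3 stands highest, its nearest neighbour being compound 2, and that gap lies beyond the usual scatter. Both measured steps start from compound 1: an at least 12-fold lower number from compound 1 to compound 2 (1.10 log units; beyond the scatter), and an at least 5.0-fold lower number from compound 1 to compound 3 (0.70 log units; beyond the scatter). Each of these starts from the limit (the limit of > 10000 nM in this assay, at which 1 of the 3 values shown sits).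

Compound 4 `CCCC1CCC(N(Cc2ccc(C(=O)NCCC(=O)O)cc2)C(=O)Nc2ccc(OC(F)(F)F)cc2)CC1` has not yet been measured. It differs from compound 3 by 4-propylcyclohexyl in place of 1-(cyclopropylcarbonyl)piperidin-4-yl on an amide-type nitrogen. Both measured steps bear on this change. Each of them, an at least 12-fold lower number from compound 1 to compound 2 (1.10 log units; beyond the scatter) and an at least 5.0-fold lower number from compound 1 to compound 3 (0.70 log units; beyond the scatter), swapped the group on this same amide-type nitrogen, and in both the number fell once a carbonyl-bearing group was present. Among the compounds with values here, compound 4 carries neither the methoxy of compound 1 nor a carbonyl on the ring; no measured compound shows a 4-propylcyclohexyl group, so the direction rests on a thin base. The step is therefore expected to be a 2.0-fold higher number from compound 3 to compound 4 (0.31 log units; beyond the scatter). Compound 4 is estimated at 4000 nM, with a range from 1000 nM to 16000 nM.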

Compound 4, half-maximal inhibitory concentration: 122 nM
For compound 4 the middle estimate is 33-fold (1.52 log units) above the measured one, outside the stated range (below it).
By their numbers in this assay, from the lowest: compound 4; then compound 2; then compound 3. At a limit, above all of these: compound 1.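

In this assay, the group on this amide-type nitrogen needs no carbonyl to reach a low number: the all-carbon 4-propylcyclohexyl gives a 16-fold lower number from compound 3 to compound 4 (1.21 log units; beyond the scatter), and this group has no hydrogen-bond acceptor, whereas 1-(cyclopropylcarbonyl)piperidin-4-yl has one. On the saturated ring carbon, the comparison with the diethylcarbamoyl group points the same way, with a 6.4-fold lower number from compound 2 to compound 4 (0.81 log units; beyond the scatter), so among the three groups shown at that carbon, propyl gives the lowest number. Against methoxy at that carbon the change is an at least 81-fold lower number from compound 1 to compound 4 (1.91 log units; beyond the scatter), a size that is only a bound because the starting value is a limit: the limit of > 10000 nM in this assay, at which 1 of the 4 values shown sits.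

The change from compound 3 to compound 4 swaps the ring and its substituent together, so the compounds shown cannot say how much of the drop belongs to each; a piperidin-4-yl ring carrying a propyl chain on its nitrogen would separate the two. From the compounds shown here alone, it also remains open whether propyl is special or any carbon chain would serve, as an ethyl or butyl chain on that ring carbon could show, and how an amine or a carboxylic acid there would compare.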